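The source may hold more compounds than are shown below. What is called first, only, known or untested is meant among the compounds shown, and "the series" means these compounds.

In a functional assay on the whole organism with Mus musculus as the target, in the maximal electroshock model, with a stated time of 1 h (a higher number here means that more compound is needed for the effect, a lower number that less compound is needed), three compounds have been measured so far:

compound 1, `Cc1ccccc1-c1nnc(N(C)N)s1`: 75 mg/kg
compound 2, `Cc1ccccc1-c1nnc(N(N)C(C)C)s1`: 54 mg/kg
compound 3, `Cc1ccccc1-c1nnc(N(N)Cc2ccccc2)s1`: 27 mg/kg

Compound 2 stands second highest of these three numbers. Among the compounds with values here, the step of a 1.4-fold lower number from compound 1 to compound 2 (0.14 log units; within the scatter) lies within the scatter, as does the step of a 2.0-fold lower number from compound 2 to compound 3 (0.30 log units; within the scatter); only the step of a 2.8-fold lower number from compound 1 to compound 3 (0.44 log units; beyond the scatter) reaches beyond it, and modestly so.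

The next compound, compound 4, `CC(C)N(N)c1nnc(-c2ccccc2Cl)s1`, differs from compound 2 in one place: chloro in place of methyl on an aromatic carbon. All three measured steps change the group on the nitrogen on the aromatic ring of the shared core and leave the six-membered aromatic ring of carbon only untouched. None of them therefore bears on the change from compound 2 to compound 4, and the data give no guidance on what exchanging methyl for chloro at that place does in this assay. With nothing to point either way, the expectation for compound 4 is a step of no more than the usual scatter in either direction, that is, an expected step of no change at the digits printed from compound 2 to compound 4 (within the scatter). For compound 4 the estimated value in this assay is therefore 54 mg/kg, with an expected range from 25 mg/kg to 115 mg/kg.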

Compound 4, dose for half-maximal effect: 54 mg/kg
The estimate for compound 4 equals the measured number at the digits printed; measured number inside the range.
By their numbers in this assay, from the lowest: compounds 3, 2, 4 and 1 (each within the scatter of the next, the first and the last beyond it).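

In this assay, the exchange of methyl for chloro on an aromatic carbon of the six-membered aromatic ring of carbon only, ortho to a large group, gives no change at the digits printed from compound 2 to compound 4 (within the scatter). Within the data shown here, this is the first step that changes this ring rather than the group on the nitrogen, and it shows that the read-out does not separate chloro from methyl at this place while isopropyl stays on the nitrogen. The result covers this one pair of compounds, and no measurement bears on why the two groups read alike here.

As far as these compounds go, whether chloro and methyl also read alike at this place when benzyl sits on the nitrogen, as in compound 3, or when methyl sits there, as in compound 1, remains open. Also open, from the compounds shown here alone, is what other groups would do on the same aromatic carbon, for example a methoxy group, a nitrile, an amine or a trifluoromethyl group, or plain hydrogen in place of any substituent.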